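The source may report more compounds than this note shows. Statements on the series, on what has been measured and on what is new or still open speak of the compounds shown alone.

Of the compounds shown here, three that share one core have been measured in an assay on CHO cells for displacement of a labelled ligand from adenosine receptor A3 (Homo sapiens), read by scintillation counting, with a stated time of 120 min, tested at 10 uM; on this read-out lower numbers stand for less inhibition and higher numbers for more inhibition at the one concentration tested (going by the name of the read-out). Compound 1 `Nc1scc(CN2CCN(c3cc(Cl)cc(Cl)c3)CC2)c1C(=O)c1ccc(Cl)cc1` gives 1%. Compound 2 `Nc1scc(CN2CCN(C3CCCCCC3)CC2)c1C(=O)c1ccc(Cl)cc1` gives 0%, and compound 3 `Nc1scc(CN2CCN(c3cccc4ccccc34)CC2)c1C(=O)c1ccc(Cl)cc1` gives 0%. The three numbers sit together: a number 1 percentage points lower from compound 1 to compound 2 (within the scatter), a number 1 percentage points lower from compound 1 to compound 3 (within the scatter) and no change at the digits printed from compound 2 to compound 3 (within the scatter) all fall within the usual scatter of repeated measurements, so none of the three can be told apart from the others. Compound 3 therefore stands level with compound 2 at the digits reported, and its gap to compound 1 is also inside the scatter.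

Compound 4 `Nc1scc(CN2CCN(c3cc(F)ccc3F)CC2)c1C(=O)c1ccc(Cl)cc1` has not been measured. It differs from compound 3 only in the group carried on the amine nitrogen in the ring: 2,5-difluorophenyl in place of naphthalen-1-yl on an amine nitrogen in a ring. Among the compounds with values here, the steps that bear on this change are those in which the same position was varied: a number 1 percentage points lower from compound 1 to compound 2 (within the scatter), a number 1 percentage points lower from compound 1 to compound 3 (within the scatter) and no change at the digits printed from compound 2 to compound 3 (within the scatter), every one of them within the scatter. Three quite different groups at this position have all given essentially the same low read-out, and nothing in these data suggests that a 2,5-difluorophenyl group should behave otherwise. The expected step is thus a number 2 percentage points higher from compound 3 to compound 4 (within the scatter), nothing beyond the scatter. Compound 4 is estimated at 2%, with a range from -8% to 12%.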

Compound 4, a percentage reported as inhibition, at one concentration (the size of the read-out at that concentration, not a potency): 2%
Beside the measured number, compound 4's estimate shows no gap at the digits printed; low and high end bracket the measured number.
By their numbers in this assay, from the lowest: compounds 2, 3, 1 and 4 (each within the scatter of the next).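

In this assay the new group gives a fourth substituent on the amine nitrogen in a ring, and the step is a number 2 percentage points higher from compound 3 to compound 4 (within the scatter) while the other two comparisons read a number 2 percentage points higher from compound 2 to compound 4 (within the scatter) and a number 1 percentage points higher from compound 1 to compound 4 (within the scatter) so none of the four compounds can be told apart. The change from naphthalen-1-yl to 2,5-difluorophenyl replaces two six-membered aromatic rings of carbon only with one such ring carrying fluorine, and this extends the flat result to a smaller aromatic group and to a fluorinated one, alongside the dichlorinated phenyl of compound 1 and the cycloheptyl of compound 2. Nothing shown here accounts for why the read-out stays this low across these groups. 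

The compounds shown leave open whether any group at this position can lift the read-out at all, such as a phenyl ring carrying a carboxylic acid or an amine, or a longer chain ending in a hydroxyl. They also leave open what happens when the 4-chlorophenyl on the carbonyl, the same in all four compounds, is replaced by another group.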